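A few compounds are considered here, and "the series" means these few. Any claim that something is new, unique, unknown or untested is made for them only; others in the source may bear on it.

- compound 1 `O=C1Nc2ccc(F)cc2/C1=C\C(=O)c1ccc(O)cc1F`: 3460 nM
- compound 2 `O=C1Nc2ccc(F)cc2/C1=C\C(=O)c1ccc[nH]1`: 2840 nM
- compound 3 `COc1ccc(C(=O)Nc2ccc3c(c2)/C(=C/Nc2cccc(N4CCN(C)CC4)c2)C(=O)N3)cc1`: 1870 nM

All three values come from a functional assay on NCI-H1650 cells (Homo sapiens) for inhibition, read by sulforhodamine B assay, with a stated time of 3 days; on this read-out lower numbers stand for stronger inhibition and higher numbers for weaker inhibition. Compound 3 lies within the usual scatter of both compound 1 and compound 2, so these numbers cannot rank the three compounds. In practice, they form a single group.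

The next compound to be tested is compound 4 `CN1CCN(c2cccc(N/C=C3\C(=O)Nc4ccc(NC(=O)c5c(Cl)cccc5Cl)cc43)c2)CC1`, which is built directly from compound 3. The change is 2,6-dichlorophenyl in place of 4-methoxyphenyl on a carbonyl carbon. In words, it is 2,6-dichlorophenyl in place of 4-methoxyphenyl on a carbonyl carbon, and the rest of the molecule stays the same.

Among the compounds with values here, no two measured compounds differ in only one place, so the data offer no direct guide to what this swap does. Compounds 1 and 2 also differ widely from compound 3 in structure, which makes them weak guides. The safest starting point is therefore compound 3 itself, at 1870 nM. The expected change is a 1.0-fold lower number from compound 3 to compound 4 (0.02 log units; within the scatter), an estimated step that stays within the scatter and favours neither direction. The uncertainty remains wide, since a single swap can sometimes matter a great deal. For compound 4 the estimated value is 1800 nM, with an expected range from 600 nM to 5500 nM.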

Compound 4, half-maximal inhibitory concentration: 2170 nM
Estimate against measurement, compound 4: 1.2-fold (0.08 log units) below, and the stated range covers the measured number.
By their numbers in this assay, from the lowest: compounds 3, 4, 2 and 1 (each within the scatter of the next).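

Within the data shown here, compound 3 and compound 4 are the first pair here that differ in one place only, so the group on this carbonyl carbon, whose other neighbour is an amide-type nitrogen, can now be judged on its own: in this assay, 2,6-dichlorophenyl in place of 4-methoxyphenyl gives a 1.2-fold higher number from compound 3 to compound 4 (0.06 log units; within the scatter). The two groups have the same heavy-atom count but differ in make-up, with two chlorine atoms entering and the methoxy oxygen, a hydrogen-bond acceptor, leaving, and even this exchange does not separate the two compounds on this read-out. No measured evidence accompanies the result to account for it.

Both groups are substituted phenyl rings, so the compounds shown leave open how this place responds to a group of another kind, such as an amine, a carboxylic acid or a longer chain on the carbonyl carbon. They also leave open whether the same swap would read alike on a different core, such as the core of compound 1.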